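This account rests on a few compounds, and the source may have more. Where it says the series, first, only, none or still open, it means among the compounds named here.

Going by the values given here, compound 2 `CCCc1ncn2c(S)nncc12` is one of only two compounds tested so far in a functional assay for inhibition, with Homo sapiens as the target; a higher number here means a weaker inhibitor, a lower number a stronger inhibitor. In this assay compound 2 gives > 48000 nM, which is a limit of the assay rather than a measured number. Compound 2 thus stands at the limit of > 48000 nM in this assay, at which 2 of the 2 values shown sit, so no inhibition has yet been seen for it. Compound 3 `CCCc1ncn2c(SC)nncc12` differs from compound 2 by methyl in place of hydrogen on a sulfur. Compound 1 `CSc1nncc2c(C(C)C)ncn12` already carries this methylsulfanyl group, with a different chain on the shared core. In this assay compound 1 gives > 48000 nM, again a limit of the assay. With both measured compounds sitting at the limit, the expected step that the limit leaves unreadable from compound 2 to compound 3 amounts to no change beyond the scatter. Compound 3 is therefore estimated at 60000 nM, with a range from 20000 nM to 200000 nM, and it is most likely to be reported once more only as a limit.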

Compound 3, half-maximal inhibitory concentration: > 48000 nM
Compound 3 was reported as a limit; the forecaster's own chance of this, stated with the estimate: 85%; the middle value does not contradict the limit.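

No step can be read from compound 2 to compound 3 or from compound 1 to compound 3, since all three compounds sit at a limit in this assay and not at a measured number: the limit of > 48000 nM in this assay, at which 3 of the 3 values shown sit. The compounds shown leave open whether any change on the shared core can bring a measurable inhibition.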